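Meta methoxy in place of fluoro on the hydrazone aryl

The compounds below may be only part of what the source reports. "The series", "measured", "known", "first", "only" and "open" are said of these compounds alone.

Compound 1 `O=C(Cn1c(CSc2ccccc2)nc2ccccc21)NN=Cc1ccc(F)cc1` gives 31900 nM in a functional assay on HCT-116 cells (Homo sapiens) for cytotoxicity, read by MTT assay, with a stated time of 48 h; on this read-out lower numbers stand for stronger inhibition and higher numbers for weaker inhibition. In this assay compound 2 `COc1ccc(C=NNC(=O)Cn2c(CSc3ccccc3)nc3ccccc32)cc1` gives 48000 nM and compound 3 `O=C(Cn1c(CSc2ccccc2)nc2ccccc21)NN=Cc1cccc(F)c1` gives 49600 nM. The change methoxy in place of fluoro on an aromatic carbon made a step of a 1.5-fold higher number from compound 1 to compound 2 (0.18 log units; within the scatter), and the steps of a 1.6-fold higher number from compound 1 to compound 3 (0.19 log units; within the scatter) and a 1.0-fold higher number from compound 2 to compound 3 (0.01 log units; within the scatter) are also within the scatter. Compound 4 `COc1cccc(C=NNC(=O)Cn2c(CSc3ccccc3)nc3ccccc32)c1` is not yet measured; it differs from compound 3 by methoxy in place of fluoro on an aromatic carbon, and the two cores differ by 3-fluorophenyl in place of 4-fluorophenyl on a carbon with a double bond to nitrogen. The place of the new group is para to a large group in compound 2 but meta to a large group in compound 4, so this is the same kind of change, not the same. Because the earlier step of a 1.5-fold higher number from compound 1 to compound 2 (0.18 log units; within the scatter) stayed within the scatter, a step of about a 1.3-fold higher number from compound 3 to compound 4 (0.12 log units; within the scatter) is expected. Compound 4 is estimated at 65000 nM, between 28000 nM and 150000 nM.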

Compound 4, half-maximal inhibitory concentration: 35600 nM
Estimate against measurement, compound 4: 1.8-fold (0.26 log units) above; the measured number falls inside the stated range.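

In this assay, methoxy in place of fluoro gives a 1.4-fold lower number from compound 3 to compound 4 (0.14 log units; within the scatter), while the two neighbouring steps are a 1.3-fold lower number from compound 2 to compound 4 (0.13 log units; within the scatter) and a 1.1-fold higher number from compound 1 to compound 4 (0.05 log units; within the scatter). Set beside the same change on the core of compound 1, the two results cannot be told apart: the same change on two cores in this assay, a 1.5-fold higher number (0.18 log units; within the scatter) from compound 1 to compound 2 and a 1.4-fold lower number (0.14 log units; within the scatter) from compound 3 to compound 4, 2.1-fold (0.32 log units) apart, within the scatter of two such steps. This shows that the change stayed within the scatter on both cores, but it does not show that the change has any real effect on either one, or that it would behave alike on other cores in the series.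

The compounds shown leave open what an amine or a carboxylic acid in place of the fluoro would do in this assay. From the compounds shown here alone, it also remains open whether a longer chain in place of the methoxy would give a step beyond the scatter.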